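A few compounds are considered here, and "the series" means these few. Any claim that something is new, unique, unknown or untested is made for them only; others in the source may bear on it.

Measured so far:
compound 1 `Brc1ccc2[nH]c(-c3cn(-c4ccccc4)nc3-c3ccccc3)nc2c1`: 1760 nM
compound 2 `Cc1ccc2[nH]c(-c3cn(-c4ccccc4)nc3-c3ccccc3)nc2c1`: 6560 nM
compound 3 `COc1ccc2[nH]c(-c3cn(-c4ccccc4)nc3-c3ccccc3)nc2c1`: 2870 nM

These values come from a functional assay on HeLa cells (Homo sapiens) for antiproliferative activity, read by MTT assay, with a stated time of 48 h; on this read-out lower numbers stand for stronger inhibition and higher numbers for weaker inhibition. Compound 2 has the highest number of the three. The nearest value gives a 2.3-fold lower number from compound 2 to compound 3 (0.36 log units; beyond the scatter), while the furthest gives a 3.7-fold higher number from compound 1 to compound 2 (0.57 log units; beyond the scatter).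

Compound 4 `Cc1cc2nc(-c3cn(-c4ccccc4)nc3-c3ccccc3)[nH]c2cc1C` is not yet measured. It differs from compound 2 by methyl in place of hydrogen on an aromatic carbon, ortho to a methyl group.

Within the data shown here, no measured step shows this change directly. The nearest evidence comes from exchanges of one group on an aromatic carbon: a 3.7-fold higher number from compound 1 to compound 2 (0.57 log units; beyond the scatter), a 2.3-fold lower number from compound 2 to compound 3 (0.36 log units; beyond the scatter) and a 1.6-fold higher number from compound 1 to compound 3 (0.21 log units; within the scatter). Across these three compounds, the steps range from within the scatter to modest. None of them adds a second group, so the data do not fix a direction for the new methyl.

In this assay, the most likely outcome is therefore no step beyond the scatter, although a modest step in either direction remains possible. The expected result is a 1.3-fold lower number from compound 2 to compound 4 (0.12 log units; within the scatter). For compound 4, the estimated value is 5000 nM, with an expected range of 2000 nM to 11000 nM.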

Compound 4, half-maximal inhibitory concentration: 41500 nM
Compound 4: the middle estimate sits 8.3-fold (0.92 log units) below what was measured; measured number outside the range, above it.
By their numbers in this assay, from the lowest: compounds 1 and 3 (each within the scatter of the next); then compound 2; then compound 4.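

In this assay, methyl in place of hydrogen on an aromatic carbon, ortho to a methyl group, gives a 6.3-fold higher number from compound 2 to compound 4 (0.80 log units; beyond the scatter), which means weaker inhibition and a step beyond the scatter. Among these compounds, the earlier compounds only exchanged one group for another on a single aromatic carbon, so this is the first sign that filling a further aromatic carbon of the same six-membered ring, with the first methyl kept, can shift the read-out on its own, and here the shift is toward weaker inhibition. No measurement on hand accounts for this loss, so the step stands as an observation only.

A single step cannot separate an effect of this carbon from an effect of methyl as the entering group, nor show whether the loss depends on the methyl already present. An amine, a hydroxyl or a carboxylic acid on this carbon, alongside the existing methyl, would test whether any added group gives weaker inhibition or only methyl does.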